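This account rests on a few compounds, and the source may have more. Where it says the series, first, only, none or still open, it means among the compounds named here.

Measured compounds:
compound 1 `CC1(C)[C@H]2CC[C@]1(C)N(Cc1cn(-c3cccc(F)c3)nn1)C(=O)C2` — 180 nM
compound 2 `Cc1ccc(-n2cc(CN3C(=O)C[C@@H]4CC[C@@]3(C)C4(C)C)nn2)cc1` — 400 nM
compound 3 `CC1(C)[C@H]2CC[C@]1(C)N(Cc1cn(-c3cccc(O)c3)nn1)C(=O)C2` — 180 nM

In a functional assay on A549 cells (Homo sapiens) for inhibition, read by MTT assay, with a stated time of 24 h (on this read-out lower numbers stand for stronger inhibition and higher numbers for weaker inhibition), compound 1 gives 180 nM. On the numbers shown compound 1 stands level with compound 3, the two together giving the lowest numbers of the three, and compound 2 gives the highest. The step of a 2.2-fold higher number from compound 1 to compound 2 (0.35 log units; beyond the scatter) is modest but beyond the scatter, whereas no change at the digits printed from compound 1 to compound 3 (within the scatter) shows no change.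

Compound 4 `Cc1ccccc1-n1cc(CN2C(=O)C[C@@H]3CC[C@@]2(C)C3(C)C)nn1` is the next compound, not yet measured. It differs from compound 1 as follows: 2-methylphenyl in place of 3-fluorophenyl on an aromatic nitrogen. For the measured compounds named here, the one measured step that bears on it is the exchange of a fluoro-bearing phenyl for a methyl-bearing phenyl on the same aromatic nitrogen, a 2.2-fold higher number from compound 1 to compound 2 (0.35 log units; beyond the scatter), a modest rise. The methyl sits at a different position of the phenyl in compound 4 than in compound 2, so that step is only a rough guide.

A modest rise of similar size, a 1.8-fold higher number from compound 1 to compound 4 (0.25 log units; within the scatter), is therefore expected, because of the step of a 2.2-fold higher number from compound 1 to compound 2 (0.35 log units; beyond the scatter). Compound 4 is estimated at 320 nM, with a range from 150 nM to 700 nM in this assay.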

Compound 4, half-maximal inhibitory concentration: 90 nM
Beside the measured number, compound 4's estimate is 3.6-fold (0.55 log units) above it; measured number outside the range, below it.
By their numbers in this assay, from the lowest: compounds 4, 1 and 3 (each within the scatter of the next); then compound 2.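

In this assay, for the compounds shown here, the earlier compounds showed a methyl on the phenyl only as 4-methylphenyl, the one group that had stood apart, and a 4.4-fold lower number from compound 2 to compound 4 (0.65 log units; beyond the scatter) shows that this higher number does not hold for 2-methylphenyl on the same aromatic nitrogen. Set against the other two groups, a 2.0-fold lower number from compound 1 to compound 4 (0.30 log units; within the scatter) and a 2.0-fold lower number from compound 3 to compound 4 (0.30 log units; within the scatter) leave 2-methylphenyl level with 3-fluorophenyl and 3-hydroxyphenyl, so among these four compounds it is the place of the methyl on the phenyl, not its presence, that goes with the change in number. Nothing available explains why the place of the methyl matters here.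

The compounds shown leave open what a phenyl carrying an amine or a carboxylic acid would give at this position. They also leave open whether an ethyl or a longer chain in place of the methyl of compound 4 would stay level with it.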